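From 3-chlorobenzyl to 2-fluorobenzyl on Two Related Cores

The compounds below may be only part of what the source reports. "The series", "measured", "known", "first", "only" and "open" are said of these compounds alone.

Compound 1 `Cc1ccc(/C=C2\CN(C(=S)SCc3cn(Cc4cccc(Cl)c4)nn3)C/C(=C\c3ccc(C)cc3)C2=O)cc1` carries a 3-chlorobenzyl group on a triazole, joined to the rest of the molecule through a thiocarbonyl-sulfur link. In a functional assay on MCF7 cells (Homo sapiens) for cytotoxicity, read by MTT assay, with a stated time of 24 h (on this read-out higher numbers stand for weaker inhibition and lower numbers for stronger inhibition), compound 1 gives only a limit, > 100000 nM, not a number. Compound 2 `Cc1ccc(/C=C2\CN(C(=S)SCc3cn(Cc4ccccc4F)nn3)C/C(=C\c3ccc(C)cc3)C2=O)cc1` differs in one place, (2-fluorophenyl in place of 3-chlorophenyl on a saturated chain carbon bound to an aromatic nitrogen). In this assay compound 2 also gives only a limit, > 100000 nM. Both compounds therefore sit at the limit of > 100000 nM in this assay, at which 2 of the 3 values shown sit, so the step that the two limits leave unreadable from compound 1 to compound 2 cannot be read.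

Compound 3 `Cc1ccc(/C=C2\CN(Cc3cn(Cc4cccc(Cl)c4)nn3)C/C(=C\c3ccc(C)cc3)C2=O)cc1` keeps the two benzylidene arms and the 3-chlorobenzyl-triazole, but the link to the ring nitrogen is different; the difference between the two cores is not broken down here. In this assay, for the measured compounds named here, compound 3 gives 10000 nM, the only number among the three measured compounds.

Compound 4 `Cc1ccc(/C=C2\CN(Cc3cn(Cc4ccccc4F)nn3)C/C(=C\c3ccc(C)cc3)C2=O)cc1` is the not yet measured partner of compound 3, differing by the same change seen between compound 1 and compound 2: 2-fluorophenyl in place of 3-chlorophenyl on a saturated chain carbon bound to an aromatic nitrogen. The earlier step gives no size to lean on, since both of its ends are limits. With nothing to suggest a shift, the step from compound 3 to compound 4 is expected to be small, no change at the digits printed from compound 3 to compound 4 (within the scatter), resting on compound 3 at 10000 nM and on the unreadable earlier step. Compound 4 is thus estimated at 10000 nM, expected to lie between 3000 nM and 40000 nM.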

Compound 4, half-maximal inhibitory concentration: 28700 nM
Compound 4: the middle estimate sits 2.9-fold (0.46 log units) below what was measured, within the range that was stated.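

In this assay, replacing 3-chlorobenzyl with 2-fluorobenzyl on the core that has no thiocarbonyl-sulfur link gives a 2.9-fold higher number from compound 3 to compound 4 (0.46 log units; beyond the scatter), so on this core the change weakens inhibition by a modest but readable margin. On the core that carries the thiocarbonyl-sulfur link, the same change cannot be read, because both of its ends are limits of the assay and not numbers: the limit of > 100000 nM in this assay, at which 2 of the 4 values shown sit. The series therefore offers one readable step on one core, with no second size to set beside it, so it neither shows that the change carries over from one core to the other nor shows that it fails to.

In this step the halogen and its place on the ring change together, so the compounds shown leave open how much of the shift belongs to each; 2-chlorobenzyl and 3-fluorobenzyl groups would separate the two. They also leave open how the plain benzyl group, a longer chain such as phenethyl, or a benzyl group bearing an amine or a carboxylic acid would read on either core.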